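Pyrazoline series: nitro substitution on the thiazole-linked phenyl

The compounds below may be only part of what the source reports. "The series", "measured", "known", "first", "only" and "open" are said of these compounds alone.

Measured so far in a functional assay on MCF7 cells (Homo sapiens) for antiproliferative activity, read by MTT assay, with a stated time of 72 h; a lower number here means a stronger inhibitor, a higher number a weaker inhibitor:
compound 1 `NC(=S)N1N=C(c2ccc(N3CCCCC3)cc2)CC1c1ccc(Cl)cc1` gives 22300 nM
compound 2 `Clc1ccc(C2CC(c3ccc(N4CCCCC4)cc3)=NN2c2nc(-c3ccccc3)cs2)cc1` gives 28400 nM

Compound 2 holds the higher of the two numbers in this assay, but the gap to compound 1 is small: a 1.3-fold higher number from compound 1 to compound 2 (0.11 log units; within the scatter). On these two numbers compound 2 and compound 1 cannot be told apart.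

Compound 3 `O=[N+]([O-])c1ccc(-c2csc(N3N=C(c4ccc(N5CCCCC5)cc4)CC3c3ccc(Cl)cc3)n2)cc1` is the next member. It differs from compound 2 in one place: nitro in place of hydrogen on an aromatic carbon.

Among the compounds with values here, no measured step touches this position; the only step on record, a 1.3-fold higher number from compound 1 to compound 2 (0.11 log units; within the scatter), replaces the thiourea with the whole phenylthiazole and sits within the scatter. Nothing here shows whether a substituent on the outer phenyl moves the number in this assay. In the absence of any step bearing on it, the expectation for compound 3 is no change beyond the scatter, in either direction, so the estimated step is a 1.1-fold lower number from compound 2 to compound 3 (0.04 log units; within the scatter). The expected value for compound 3 in this assay is therefore 26000 nM, with a range from 10000 nM to 70000 nM.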

Compound 3, half-maximal inhibitory concentration: > 100000 nM
Compound 3 ended at the assay's limit; the forecaster's own chance of this, stated with the estimate: 15%; at least 3.8-fold (0.58 log units) between middle value and limit.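

In this assay, within the data shown here, the outer phenyl of the phenylthiazole is not a silent position: the change from phenyl to 4-nitrophenyl gives an at least 3.5-fold higher number from compound 2 to compound 3 (0.54 log units; beyond the scatter) and is the only step so far that lies beyond the scatter. Compound 3 gives > 100000 nM as a limit of the assay and not as a number. The replacement of the thiourea by the whole phenylthiazole left the number within the scatter, whereas nitro on an aromatic carbon of that phenyl, para to a large group, takes the series out of the measurable range, so the real size of the step stays unknown because the reading stops at the limit: the limit of > 100000 nM in this assay, at which 1 of the 3 values shown sits.

Open, going by these compounds, is whether this loss belongs to nitro itself or to any substituent at this place, and an amine, a nitrile or a methyl group on the same aromatic carbon would separate those two readings. Also open, on these data alone, is whether any group here moves the number the other way, towards a stronger inhibitor than the unsubstituted phenyl of compound 2.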